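The compounds below may be only part of what the source reports. "The series", "measured", "known", "first", "only" and "open" are said of these compounds alone.

Within the data shown here, compound 3 `O=C(OC1(C(=O)Nc2ccc([N+](=O)[O-])cc2)CCCCC1)c1ccc([N+](=O)[O-])cc1` stands lowest of the three numbers measured so far: in a functional assay on HepG2 cells (Homo sapiens) for inhibition, read by MTT assay, with a stated time of 72 h (a higher number here means a weaker inhibitor, a lower number a stronger inhibitor), compound 3 gives 14.1 nM, while compound 1 `O=C(OC1(C(=O)Nc2ccc([N+](=O)[O-])cc2)CCCCC1)c1ccc(C(F)(F)F)cc1` gives 29.1 nM and compound 2 `COc1ccc(C(=O)OC2(C(=O)Nc3ccc([N+](=O)[O-])cc3)CCCCC2)cc1` gives 57.1 nM. Its separation from the others is modest, a 2.1-fold lower number from compound 1 to compound 3 (0.31 log units; beyond the scatter) and a 4.0-fold lower number from compound 2 to compound 3 (0.61 log units; beyond the scatter). Compound 4 `CC(=O)Oc1ccccc1C(=O)OC1(C(=O)Nc2ccc([N+](=O)[O-])cc2)CCCCC1` differs from compound 3 by 2-acetoxyphenyl in place of 4-nitrophenyl on a carbonyl carbon. The measured steps that bear on this are the swaps on the same aromatic carbon, a 2.0-fold higher number from compound 1 to compound 2 (0.29 log units; within the scatter) and a 2.1-fold lower number from compound 1 to compound 3 (0.31 log units; beyond the scatter), both small, and none of them covers an acetoxy group. Removing the nitro group is expected to raise the number by about the size of those steps, a 3.2-fold higher number from compound 3 to compound 4 (0.50 log units; beyond the scatter). Compound 4 is therefore estimated at 45 nM, with a range from 15 nM to 130 nM.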

Compound 4, half-maximal inhibitory concentration: 17.7 nM
Compound 4: the middle estimate sits 2.5-fold (0.41 log units) above what was measured, and the stated range covers the measured number.
By their numbers in this assay, from the lowest: compounds 3, 4, 1 and 2 (each within the scatter of the next, the first and the last beyond it).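

On the carbonyl carbon, 2-acetoxyphenyl in place of 4-nitrophenyl gives a 1.3-fold higher number from compound 3 to compound 4 (0.10 log units; within the scatter), so in this assay a number in this range does not depend on the nitro group of 4-nitrophenyl. The same group gives a 3.2-fold lower number from compound 2 to compound 4 (0.51 log units; beyond the scatter) and a 1.6-fold lower number from compound 1 to compound 4 (0.22 log units; within the scatter), the first beyond the scatter and the second within it. Nothing at hand explains these steps. Open, on these data alone, is how a plain phenyl or a 2-hydroxyphenyl on this carbonyl carbon would compare with 2-acetoxyphenyl, and how an amine or a carboxylic acid on that aromatic ring would read.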